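Chain extension on the fluorophenyl carbamate: compound 3

The source may hold more compounds than are shown below. What is called first, only, known or untested is meant among the compounds shown, and "the series" means these compounds.

Compound 2 `CC(C)=CCC1Cc2c(OC(=O)Nc3cccc(F)c3)cc(=O)n(CCCO)c2CC1(C)C` carries a 3-fluorophenyl carbamate on the shared core. In a functional assay on PANC-1 cells (Homo sapiens) for inhibition, read by MTT assay, with a stated time of 24 h, tested at 10 uM (on this read-out higher numbers stand for more inhibition at the one concentration tested (going by the name of the read-out) and lower numbers for less inhibition), compound 2 gives 0%. Its nearest measured neighbour, compound 1 `COc1ccc(NC(=O)Oc2cc(=O)n(CCCO)c3c2CC(CC=C(C)C)C(C)(C)C3)cc1`, gives 0% in this assay, and the step of no change at the digits printed from compound 1 to compound 2 (within the scatter) shows that exchanging the aryl group of the carbamate left the read-out where it stood. Compound 3 `CC(C)=CCC/C(C)=C/CC1Cc2c(OC(=O)Nc3cccc(F)c3)cc(=O)n(CCCO)c2CC1(C)C` keeps the 3-fluorophenyl carbamate of compound 2 and changes only the side chain: 3-methylbut-2-en-1-yl in place of hydrogen on a saturated chain carbon bound to a double-bonded chain carbon. Within the data shown here, no measured pair probes this chain; the only measured step concerns the carbamate aryl group and does not bear on it. Among the measured compounds shown here, with both measured compounds at the floor of the read-out and no precedent for a chain change, no movement beyond the scatter is expected. Compound 3 is therefore estimated at 4% in this assay, with a range from 0% to 18%. The expected step is a number 4 percentage points higher from compound 2 to compound 3 (within the scatter).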

Compound 3, a percentage reported as inhibition, at one concentration (the size of the read-out at that concentration, not a potency): 0%
Beside the measured number, compound 3's estimate is 4 percentage points above it, within the range that was stated.
By their numbers in this assay, from the lowest: compounds 1, 2 and 3 (each within the scatter of the next).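

Putting 3-methylbut-2-en-1-yl in place of hydrogen on a saturated chain carbon bound to a double-bonded chain carbon gives no change at the digits printed from compound 2 to compound 3 (within the scatter) in this assay, so the side chain, which the earlier step left untouched, has now also been varied without moving the read-out. With compound 3 at 0%, the 3,7-dimethylocta-2,6-dien-1-yl chain gives no direction for further work on this position. No evidence bearing on this result is available.

Open, going by these compounds, is whether an amine or a carboxylic acid on the side chain, or a urea in place of the carbamate, would lift the read-out off this floor. Also open, on these data alone, is whether the two chains would separate with a different carbamate aryl group.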